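The source may report more compounds than this note shows. Statements on the series, on what has been measured and on what is new or still open speak of the compounds shown alone.

Measured compounds:

Compound 1, `O=C(NC1CCN(C2CC2)C1)c1cc(-c2ccc(NS(=O)(=O)c3cccc(Cl)c3Cl)cc2)nc2[nH]ncc12`, gives 610 nM.
Compound 2, `Cc1n[nH]c2nc(-c3ccc(NS(=O)(=O)c4cc(Cl)ccc4F)cc3)nc(OCCC(=O)N(C)C)c12`, gives 438 nM.

Both numbers come from an assay for inhibition of serine/threonine-protein kinase Sgk1 (Homo sapiens), with stated times of 30 min and 60 min, in the presence of a further agent that is not named here; on this read-out lower numbers stand for stronger inhibition and higher numbers for weaker inhibition. Going by the values given here, compound 1 and compound 2 have different cores and different side groups, so no single step separates them, and their two numbers lie within the usual scatter of each other; on this read-out the two compounds cannot be told apart, and compound 2 is simply one of two values that sit close together.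

Compound 3, `Cc1n[nH]c2nc(-c3ccc(NS(=O)(=O)c4cc(Cl)ccc4F)cc3)nc(OCC(CO)CO)c12`, keeps the core and the sulfonamide part of compound 2 and changes only the chain on the ether oxygen: 2-hydroxy-1-(hydroxymethyl)ethyl in place of (dimethylcarbamoyl)methyl on a saturated chain carbon bound to an oxygen on an aromatic ring. Among the compounds with values here, no measured pair shows what this kind of change does to this assay, so the direction is open. Within the data shown here, the chain that leaves and the chain that enters have similar size, and nothing among the measured compounds points to a large move either way. The step of a 1.1-fold higher number from compound 2 to compound 3 (0.06 log units; within the scatter) is therefore expected to be small, none beyond the scatter. Compound 3 is estimated to give 500 nM, with a range from 150 nM to 1700 nM.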

Compound 3, half-maximal inhibitory concentration: 2 nM
Compound 3: the middle estimate sits 250-fold (2.40 log units) above what was measured; the measured number lies below the stated range.
By their numbers in this assay, from the lowest: compound 3; then compounds 2 and 1 (each within the scatter of the next).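

In this assay, the chain on the ether oxygen turns out to be a highly sensitive part of the molecule: with the core and the sulfonamide part unchanged, placing 2-hydroxy-1-(hydroxymethyl)ethyl in place of (dimethylcarbamoyl)methyl gives a 220-fold lower number from compound 2 to compound 3 (2.34 log units; beyond the scatter). This large step comes with little change in chain size, 6 heavy atoms leaving and 5 entering, while the counts show 0 hydrogen-bond donors leaving and 2 entering, and the carbonyl and the nitrogen of the amide are gone. Nothing available here explains why the step is so large.

The compounds shown leave open which part of the change carries the step: a 2-hydroxyethyl chain, with a single hydroxyl, would test whether both hydroxyl groups matter, and a 2-aminoethyl chain or a chain ending in a carboxylic acid would show whether other groups on the same oxygen can do the same. Also open, as far as these compounds go, is whether the 2-hydroxy-1-(hydroxymethyl)ethyl chain would give a comparable step on a different core, such as the core of compound 1.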